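This account rests on a few compounds, and the source may have more. Where it says the series, first, only, none or still open, it means among the compounds named here.

In a functional assay on K562 cells (Homo sapiens) for cytotoxicity, with a stated time of 72 h (on this read-out lower numbers stand for stronger inhibition and higher numbers for weaker inhibition), compound 1 `Cc1cc(-c2c(-c3cccc(C)n3)nn3c2C(C)C(C)(C)C3)ccn1` gives > 100000 nM, which is a limit of the assay and not a number. Compound 2 `CC1(C)Cc2c(-c3ccncc3)c(-c3ccccc3C#N)nn2C1` gives > 100000 nM, which is also a limit. Compound 1 therefore stands at the limit of > 100000 nM in this assay, at which 2 of the 2 values shown sit, and there is neither a measured number nor a measured step to build on.

Compound 3 `Cc1cccc(-c2nn3c(c2-c2ccnc(Nc4ccc(S(N)(=O)=O)cc4)c2)C(C)C(C)(C)C3)n1` differs from compound 1 in one place: (4-sulfamoylphenyl)amino in place of methyl on an aromatic carbon. Put simply, (4-sulfamoylphenyl)amino replaces methyl on an aromatic carbon, next to the ring nitrogen. For the measured compounds named here, the entering group is far larger than the methyl it replaces, but no measured pair shows what such a change does in this assay.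

The expectation is therefore a tentative one: a sizeable move towards lower numbers, meaning stronger inhibition, although a result that again reaches only the limit remains quite possible. The expected change is an at least 5.0-fold lower number from compound 1 to compound 3 (0.69 log units; beyond the scatter). For compound 3, the estimated value is 20000 nM, with an expected range from 2500 nM to 100000 nM.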

Compound 3, half-maximal inhibitory concentration: 31000 nM
Beside the measured number, compound 3's estimate is 1.6-fold (0.19 log units) below it; low and high end bracket the measured number.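

For the compounds shown here, replacing methyl with (4-sulfamoylphenyl)amino on an aromatic carbon, next to the ring nitrogen, gives in this assay an at least 3.2-fold lower number from compound 1 to compound 3 (0.50 log units; beyond the scatter), the only step so far that can be read at all. This position can therefore carry a far larger group than methyl, one with its own aromatic ring, and still yield a measured number, though compound 3 at 31000 nM remains a weak inhibitor in absolute terms. Compound 1 and compound 2 stay at a limit of the assay and not at a number, leaving compound 3 as the only measured value: the limit of > 100000 nM in this assay, at which 2 of the 3 values shown sit.

The compounds shown leave open which part of the entering group accounts for the step: a plain amine at this position, a phenylamino group without the sulfamoyl, or a carboxylic acid in place of the sulfamoyl would begin to separate these parts. As far as these compounds go, the full size of the step also stays open, with compound 1 known only as a limit, and so does whether the same group would act alike on the core of compound 2.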